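The source may report more compounds than this note shows. Statements on the series, on what has been measured and on what is new or still open speak of the compounds shown alone.

Compound 1 `O=C(OCCc1ccc(Cl)c(Cl)c1)N(c1ccccc1)C1CN2CCC1CC2`: 80 nM in an assay on CHO cells for displacement of a labelled ligand from muscarinic acetylcholine receptor M5 (Homo sapiens), read by scintillation counting, with a stated time of 2 h; on this read-out higher numbers stand for weaker inhibition and lower numbers for stronger inhibition. Compound 2 `COc1ccc(CCCOC(=O)N(c2ccccc2)C2CN3CCC2CC3)cc1`: 640 nM. Compound 3 `O=C(OCCCc1ccc(F)c(F)c1)N(c1ccccc1)C1CN2CCC1CC2`: 100 nM.

Compound 3 sits between the other two: its number is close to that of compound 1, with a 1.3-fold higher number from compound 1 to compound 3 (0.10 log units; within the scatter), while the gap to compound 2 is larger, with a 6.4-fold lower number from compound 2 to compound 3 (0.81 log units; beyond the scatter). Compound 4 `O=C(OCCc1ccccc1)N(c1ccccc1)C1CN2CCC1CC2` differs from compound 3 in one place: phenyl in place of 3,4-difluorobenzyl on a saturated chain carbon, two bonds along the chain from an oxygen next to a carbonyl group. Among the compounds with values here, no measured step removes both halogens from the ring, so the closest guide is an 8.0-fold higher number from compound 1 to compound 2 (0.90 log units; beyond the scatter), where replacing the dichlorinated ring weakened binding, and a 1.3-fold higher number from compound 1 to compound 3 (0.10 log units; within the scatter), where swapping halogens barely mattered. A modest weakening is therefore expected, a 2.2-fold higher number from compound 3 to compound 4 (0.34 log units; beyond the scatter). Compound 4 is estimated at 220 nM, between 70 nM and 700 nM.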

Compound 4, inhibition constant: 260 nM
Compound 4: the middle estimate sits 1.2-fold (0.07 log units) below what was measured, and the stated range covers the measured number.
By their numbers in this assay, from the lowest: compounds 1 and 3 (each within the scatter of the next); then compound 4; then compound 2.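

Removing the substituents from the ring weakens binding in this assay (a 3.3-fold higher number from compound 1 to compound 4 (0.51 log units; beyond the scatter); a 2.6-fold higher number from compound 3 to compound 4 (0.41 log units; beyond the scatter)), so the two halogenated groups give stronger binding at this position than the bare phenyl. The bare phenyl still beats the 4-methoxybenzyl group (a 2.5-fold lower number from compound 2 to compound 4 (0.39 log units; beyond the scatter)), so adding a substituent to this ring does not by itself strengthen binding. No supporting data explain these differences. Going by these compounds, it remains open how an amine or a carboxylic acid on this ring would compare, and how a longer chain would behave.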